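The source may hold more compounds than are shown below. What is called first, only, known or untested is meant among the compounds shown, and "the series" means these compounds.

Measured so far in an ADME assay on microsomes from liver (Mus musculus, strain CD1) for metabolic stability, read by HPLC, using NADPH, with a stated time of 30 min, tested at 0.5 uM; a lower number here means slower removal, a higher number faster removal of the compound:
- compound 1 `CC(=O)Nc1cnc2[nH]c(=O)n([C@H]3CC[C@H](C(C)(C)C)CC3)c(=O)c2c1` gives 1.4 mL.min-1.g-1
- compound 2 `CC(=O)Nc1cnc2[nH]c(=O)n([C@H]3CC[C@@H](C(C)(C)C)CC3)c(=O)c2c1` gives 15 mL.min-1.g-1
- compound 3 `CC(=O)Nc1cnc2[nH]c(=O)n([C@H]3CC[C@H](C(C)C)CC3)c(=O)c2c1` gives 1.4 mL.min-1.g-1

Compound 1 stands level with compound 3, and together they hold the lowest of the three numbers. Next in line is compound 4 `CC(C)(C)[C@H]1CC[C@H](n2c(=O)[nH]c3ncc(N)cc3c2=O)CC1`, which departs from compound 1 by hydrogen in place of acetyl on a nitrogen on an aromatic ring, so that acetamido becomes amino.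

Neither measured step touches the acetamido group. The step of no change at the digits printed from compound 1 to compound 3 (within the scatter) stays within the scatter and concerns the alkyl group on the saturated ring. The step of an 11-fold higher number from compound 1 to compound 2 (1.03 log units; beyond the scatter) is large, and there the fact that compounds 1 and 2 differ only in the configuration as drawn is the whole difference. These steps give no direct size for the change at hand and show only the span the number has covered so far in this assay. With compound 1 at the low end of that span, a moderate rise is expected, smaller than the configuration step, although no change beyond the scatter remains possible. The estimate amounts to a 2.1-fold higher number from compound 1 to compound 4 (0.33 log units; beyond the scatter) as the expected move. Compound 4 is expected at 3 mL.min-1.g-1, within an estimated range of 1 mL.min-1.g-1 to 9 mL.min-1.g-1 for now.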

Compound 4, intrinsic clearance in microsomes: 0.5 mL.min-1.g-1
For compound 4 the middle estimate is 6.0-fold (0.78 log units) above the measured one; measured number below the stated range.
By their numbers in this assay, from the lowest: compound 4; then compounds 1 and 3 (each within the scatter of the next); then compound 2.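

In this assay, within the data shown here, the acetamido to amino change gives a 2.8-fold lower number from compound 1 to compound 4 (0.45 log units; beyond the scatter) and is the first step in these compounds that lowers the number beyond the scatter. The number at compound 1 is therefore not a floor for this alkyl group and configuration, and the acetyl on the nitrogen on the aromatic ring is not required for slow removal here. What is known so far offers no explanation for the size or direction of this step.

Open, as far as these compounds go, is whether the same change lowers the number with the alkyl group of compound 3 or the configuration of compound 2. Also open, from the compounds shown here alone, is how other groups on this nitrogen would read, such as a propionyl, a methyl carbamate or a methyl on the amine.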